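Series notes: chloro to trifluoromethyl on the aromatic ring

A few compounds are considered here, and "the series" means these few. Any claim that something is new, unique, unknown or untested is made for them only; others in the source may bear on it.

Two compounds are in hand. Compound 1 `CC(=O)n1nc(C)c(-c2ccc(Cl)c(Cl)c2)c1N` is the dichloro member; in an assay on Sf9 cells for inhibition of inhibitor of nuclear factor kappa-B kinase subunit epsilon (Homo sapiens), read by ADP-Glo, with a stated time of 60 min (a lower number here means a stronger inhibitor, a higher number a weaker inhibitor), compound 1 gives > 100000 nM, which is a limit of the assay and not a number. Compound 2 `CC(=O)n1nc(C)c(-c2cccc(Cl)c2)c1N` drops one chloro. In this assay compound 2 gives > 100000 nM, again a limit. The step that the two limits leave unreadable from compound 1 to compound 2 is unreadable, since both values sit at the limit of > 100000 nM in this assay, at which 2 of the 2 values shown sit. Compound 2 thus stands at the limit, with nothing further known about it.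

Compound 3 `CC(=O)n1nc(C)c(-c2cccc(C(F)(F)F)c2)c1N` differs from compound 2 by trifluoromethyl in place of chloro on an aromatic carbon. Among the measured compounds shown here, no measured step bears on this change; the only step cannot be sized, and both its ends rest at the limit. The expectation for compound 3 can rest only on where compound 2 stands, so no step beyond the scatter is expected in this assay and a limit is the likeliest outcome. Compound 3 is expected at 100000 nM, with a range from 30000 nM to 300000 nM. The expected step of a number no higher from compound 2 to compound 3 (the limit leaves the size open) is therefore essentially nil.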

Compound 3, half-maximal inhibitory concentration: > 100000 nM
Compound 3: no number, only a limit (the forecaster's own chance of this, stated with the estimate: 85%); the middle value sits exactly at the limit.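

No step can be read between compound 2 and compound 3, as each gives a limit of the assay and not a number: the limit of > 100000 nM in this assay, at which 3 of the 3 values shown sit.

The compounds shown leave open whether chloro and trifluoromethyl differ at all in this assay, and how far any of the three lies past the limit.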